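Ester and acid on a thiophene core in a gastric line

This account rests on a few compounds, and the source may have more. Where it says the series, first, only, none or still open, it means among the compounds named here.

The study compares four compounds on one core in a functional assay on SGC-7901 cells (Homo sapiens) for antiproliferative activity, read by MTT assay, with a stated time of 72 h; on this read-out higher numbers stand for weaker inhibition and lower numbers for stronger inhibition. Compound 1 `CCOC(=O)c1cc(-c2cc(OC)c(OC)c(OC)c2)c(-c2cccc(Br)c2)s1` reaches only the limit of this assay, > 100000 nM, a limit and not a number. Compound 2 `COc1cc(-c2cc(C(=O)O)sc2-c2cccc(Br)c2)cc(OC)c1OC` gives 93400 nM, and the change from compound 1 to compound 2 is hydrogen in place of ethyl on an oxygen next to a carbonyl group. The size of this step is an at least 1.0-fold lower number from compound 1 to compound 2 (0.02 log units; that floor lies within the scatter); it is bounded by compound 1 sitting at the limit of this assay (the limit of > 100000 nM in this assay, at which 1 of the 3 values shown sits).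

Compound 3 `CCOC(=O)c1cc(-c2ccc(OC)cc2)c(-c2cc(OC)c(OC)c(OC)c2)s1` gives 6820 nM, the lowest of the two numbers measured; how its core differs from that of compound 1 is not broken down here. Compound 4 `COc1ccc(-c2cc(C(=O)O)sc2-c2cc(OC)c(OC)c(OC)c2)cc1` has not yet been measured in this assay; its difference from compound 3 is hydrogen in place of ethyl on an oxygen next to a carbonyl group, the same change as from compound 1 to compound 2.

Compound 4 is expected to move by a 1.8-fold higher number from compound 3 to compound 4 (0.25 log units; within the scatter), an estimate that rests on the small measured step of an at least 1.0-fold lower number from compound 1 to compound 2 (0.02 log units; that floor lies within the scatter) and on compound 3 with its value 6820 nM. For compound 4 the expected value is therefore 12000 nM, with a range from 4000 nM to 40000 nM.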

Compound 4, half-maximal inhibitory concentration: 4220 nM
Compound 4: middle estimate off by 2.8-fold (0.45 log units), on the high side, within the range that was stated.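

The change from ethoxycarbonyl to carboxy on the core of compound 3 gives a 1.6-fold lower number from compound 3 to compound 4 (0.21 log units; within the scatter) in this assay, a step that does not separate the ester from the acid on this core. Set beside the same change on the core of compound 1, the result on carrying it over is this: the same change on two cores in this assay, an at least 1.0-fold lower number (0.02 log units; that floor lies within the scatter) from compound 1 to compound 2 and a 1.6-fold lower number (0.21 log units; within the scatter) from compound 3 to compound 4; the limit leaves it open whether they differ. The pair on the core of compound 3 thus gives a readable size for the step, while the pair on the core of compound 1 gives only a floor, so the series does not show that the change carries a fixed size from one core to another: the limit of > 100000 nM in this assay, at which 1 of the 4 values shown sits.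

The compounds shown leave open whether an amide, or a longer chain than ethyl on the same oxygen, would read like the ester and the acid on these cores. They also leave open whether the ester and the acid would stay this close on a core carrying an amine.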